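Adding an Ester Chain to a Weak Tracheal Inhibitor

The compounds below may be only part of what the source reports. "The series", "measured", "known", "first", "only" and "open" are said of these compounds alone.

Compound 1 `Cn1nc(-c2cccnc2)c2ccccc2c1=O`: 11500 nM
Compound 2 `CCCn1nc(-c2cccnc2)c2ccccc2c1=O`: 3160 nM
Compound 3 `COCCn1nc(-c2cccnc2)c2ccccc2c1=O`: 9330 nM

All three share one core and differ only in the group on the saturated chain carbon bound to the aromatic nitrogen. In a functional assay (trachea) with Cavia porcellus as the target (a lower number here means a stronger inhibitor, a higher number a weaker inhibitor), compound 1 stands at the highest number of the three, so it is the weakest inhibitor shown, although its gap to compound 3 lies within the scatter. The step of a 3.6-fold lower number from compound 1 to compound 2 (0.56 log units; beyond the scatter) is a modest gain, while a 1.2-fold lower number from compound 1 to compound 3 (0.09 log units; within the scatter) is no real change, and a 3.0-fold higher number from compound 2 to compound 3 (0.47 log units; beyond the scatter) shows that swapping methyl for methoxy on that chain gives the number back.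

Compound 4 `CCOC(=O)Cn1nc(-c2cccnc2)c2ccccc2c1=O` carries ethoxycarbonyl in place of hydrogen on a saturated chain carbon bound to an aromatic nitrogen. The two steps that bear on it are those from compound 1 to compound 2 and to compound 3: a chain of plain carbon gave a modest gain, a chain holding oxygen gave none. The entering group is longer than either and holds two oxygen atoms, closer to the case of compound 3. The expectation is therefore a step of a 1.4-fold lower number from compound 1 to compound 4 (0.16 log units; within the scatter), small and within the scatter. Compound 4 is estimated at 8000 nM, in a range from 3000 nM to 20000 nM.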

Compound 4, half-maximal inhibitory concentration: 43700 nM
Compound 4: middle estimate off by 5.5-fold (0.74 log units), on the low side; the measured number lies above the stated range.
By their numbers in this assay, from the lowest: compound 2; then compounds 3 and 1 (each within the scatter of the next); then compound 4.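

In this assay, among the compounds shown here, ethoxycarbonyl is the first group at this place on the chain to make the inhibitor clearly weaker, with a 3.8-fold higher number from compound 1 to compound 4 (0.58 log units; beyond the scatter) making this the weakest of the four, so this position can lose activity as well as hold or gain it. Oxygen in the chain does not settle the outcome by itself, as both groups hold it and there is still a 4.7-fold higher number from compound 3 to compound 4 (0.67 log units; beyond the scatter) between them, while a 14-fold higher number from compound 2 to compound 4 (1.14 log units; beyond the scatter) shows how wide the range at this one position is. Nothing measured here gives a reason for these steps.

From the compounds shown here alone, whether the ethyl end of the ester matters stays open, since a carboxylic acid or an amide in its place could land near compound 4 or well away from it. Going by these compounds, it also remains open whether a longer plain carbon chain, such as butyl, would give a lower number than compound 2 does.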